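Swapping the Ketone Aryl Group on a Shared Core

The source may report more compounds than this note shows. Statements on the series, on what has been measured and on what is new or still open speak of the compounds shown alone.

Measured so far:
compound 1, `O=C(/C=C/c1ccc2c(c1)B(O)OC2)c1ccc(-c2ccccc2)cc1`: 9500 nM
compound 2, `Cn1cccc1C(=O)/C=C/c1ccc2c(c1)B(O)OC2`: > 100000 nM

In a functional assay on HCT-116 cells (Homo sapiens) for cytotoxicity, read by MTT assay, with a stated time of 48 h (a lower number here means a stronger inhibitor, a higher number a weaker inhibitor), compound 1 gives 9500 nM. Compound 2 reaches only a limit of the assay, > 100000 nM, and so stands at the limit of > 100000 nM in this assay, at which 1 of the 2 values shown sits. The move to compound 3, `O=C(/C=C/c1ccc2c(c1)B(O)OC2)c1ccccc1O`, is 2-hydroxyphenyl in place of 1-methyl-1H-pyrrol-2-yl on a carbonyl carbon. For the measured compounds named here, no measured step shows what this swap does, so the expectation is uncertain, but compound 3 is expected to come back into the measurable range, an estimated step of an at least 2.5-fold lower number from compound 2 to compound 3 (0.39 log units; beyond the scatter). Compound 3 is expected to give about 40000 nM, between 10000 nM and 150000 nM.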

Compound 3, half-maximal inhibitory concentration: 77900 nM
Beside the measured number, compound 3's estimate is 1.9-fold (0.29 log units) below it, within the range that was stated.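

In this assay compound 3 gives a measured number, which shows that a group on this carbonyl carbon can bring the shared core back inside the range the assay can read. Compound 2 stands only at a limit of the assay (> 100000 nM). From the compounds shown here alone, the swap to 2-hydroxyphenyl can therefore be read only as a floor (an at least 1.2-fold lower number from compound 2 to compound 3 (0.10 log units; that floor lies within the scatter)), and its true size stays unknown.

Still open, going by these compounds, is whether the hydroxy group or the six-membered ring itself accounts for the change. Also open, on these data alone, is how a ring carrying an amine or a carboxylic acid would read here.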